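Chloro step from compound 3: working notes

The source may hold more compounds than are shown below. What is called first, only, known or untested is meant among the compounds shown, and "the series" means these compounds.

Measured so far in a functional assay on BT-549 cells (Homo sapiens) for inhibition, read by sulforhodamine B assay, with a stated time of 48 h; on this read-out higher numbers stand for weaker inhibition of growth and lower numbers for stronger inhibition of growth
- compound 1 `Cc1nnc(-c2nn(-c3ccccc3)c(-c3ccccc3)c2C#N)c2cn(-c3ccccc3)nc12` gives 96800 nM
- compound 2 `N#Cc1c(-c2nnc(O)c3nn(-c4ccc(Cl)cc4)cc23)nn(-c2ccccc2)c1-c1ccccc1` gives > 100000 nM as a limit of the assay
- compound 3 `N#Cc1c(-c2nnc(-c3nn(-c4ccccc4)c(-c4ccccc4)c3C#N)c3nn(-c4ccccc4)cc23)nn(-c2ccccc2)c1-c1ccccc1` gives 11800 nM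

Compound 3 holds the lower of the two actual numbers, and compound 1 (96800 nM) lies above it, beyond the scatter. Compound 2 offers only a limit. Compound 4 `N#Cc1c(-c2nnc(-c3nn(-c4ccccc4)c(-c4ccccc4)c3C#N)c3nn(-c4ccc(Cl)cc4)cc23)nn(-c2ccccc2)c1-c1ccccc1` differs from compound 3 by chloro in place of hydrogen on an aromatic carbon as phenyl to 4-chlorophenyl: chloro in place of hydrogen on an aromatic carbon, para to a large group. Going by the values given here, no measured pair shows this change. No shift beyond the scatter is expected in this assay and the estimated 1.2-fold lower number from compound 3 to compound 4 (0.07 log units; within the scatter) is small and slightly downward. This expectation rests on compound 3 (11800 nM) alone. For compound 4 the estimated value is 10000 nM (range 4000 nM to 30000 nM).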

Compound 4, concentration for 50% growth inhibition: 1020 nM
Beside the measured number, compound 4's estimate is 9.8-fold (0.99 log units) above it, outside the stated range (below it).
By their numbers in this assay, from the lowest: compound 4; then compound 3; then compound 1. At a limit, above all of these: compound 2.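

In this assay, going by these compounds alone, the change from phenyl to 4-chlorophenyl gives a 12-fold lower number from compound 3 to compound 4 (1.06 log units; beyond the scatter), the only step so far between compounds that differ in one place, so substitution on this aromatic carbon, para to a large group, can move the read-out beyond the scatter. A single added chlorine atom is enough for this. Nothing shown gives a cause for the step.

Still open, as far as these compounds go, is whether fluoro, methoxy or an amine at the same place would give a similar step. Also open, from the compounds shown here alone, is whether chloro on the other phenyl rings would do the same.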